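Shortening the Chain of Compound 1

The source may report more compounds than this note shows. Statements on the series, on what has been measured and on what is new or still open speak of the compounds shown alone.

Compound 1 `CCCCCC(=O)NCC(=O)N(C)c1ccc(Cl)cc1C(=O)c1ccccc1Cl`: 90 mg/kg
Compound 2 `NCC(=O)NCC(=O)Nc1ccc([N+](=O)[O-])cc1C(=O)c1ccccc1`: 24.8 mg/kg
Compound 3 `NCC(=O)NCC(=O)Nc1ccc([N+](=O)[O-])cc1C(=O)c1ccccc1Cl`: 63.9 mg/kg

In a functional assay on the whole organism with Mus musculus as the target, in the rotarod test (on this read-out higher numbers stand for an effect only at larger amounts of compound and lower numbers for an effect already at smaller amounts), compound 1 gives 90 mg/kg, within the scatter of compound 3, while compound 2 shows a clearly lower number. Compound 4 `CCC(=O)NCC(=O)N(C)c1ccc(Cl)cc1C(=O)c1ccccc1Cl` keeps the core of compound 1 but carries one change: hydrogen in place of propyl on a saturated chain carbon, two bonds along the chain from a carbonyl carbon. In words, pentylcarbonyl becomes propanoyl. Among the measured compounds shown here, no measured step touches this chain. The only one, a 2.6-fold higher number from compound 2 to compound 3 (0.41 log units; beyond the scatter), places chloro on an aromatic carbon, so it bears only indirectly, as a sign that one small change can move this read-out modestly. The estimated change is a 1.2-fold lower number from compound 1 to compound 4 (0.08 log units; within the scatter), so no step beyond the scatter is expected. Compound 4 is expected near 75 mg/kg, with an estimated range of 35 mg/kg to 150 mg/kg.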

Compound 4, dose for half-maximal effect: 36 mg/kg
For compound 4 the middle estimate is 2.1-fold (0.32 log units) above the measured one; low and high end bracket the measured number.
By their numbers in this assay, from the lowest: compounds 2, 4, 3 and 1 (each within the scatter of the next, the first and the last beyond it).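

Removing propyl from the chain, with the rest of compound 1 unchanged, gives in this assay a 2.5-fold lower number from compound 1 to compound 4 (0.40 log units; beyond the scatter). Among the compounds shown here, this is the first measured step at this position, and it shows that the read-out responds to the chain alone, with the core of compound 1 left intact. Nothing at hand explains why the number falls.

This single pair cannot establish a trend with chain length. On these data alone, how acetyl or a carboxylic acid would read in place of propanoyl remains open.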